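Adding a second fluoro to compound 3

A few compounds are considered here, and "the series" means these few. Any claim that something is new, unique, unknown or untested is made for them only; others in the source may bear on it.

- compound 1 `CC(C)[C@H](NC(=O)COc1cccc2ccccc12)C(=O)N[C@@H](CC(=O)O)C(=O)COc1ccc(C(F)(F)F)cc1`: 12300 nM
- compound 2 `CC(C)[C@H](NC(=O)COc1cccc2ccccc12)C(=O)N[C@@H](CC(=O)O)C(=O)COc1ccc([N+](=O)[O-])cc1`: 22800 nM
- compound 3 `CC(C)[C@H](NC(=O)COc1cccc2ccccc12)C(=O)N[C@@H](CC(=O)O)C(=O)COc1ccccc1F`: 15700 nM

These three values come from a functional assay with Homo sapiens as the target; on this read-out higher numbers stand for weaker inhibition and lower numbers for stronger inhibition. The compounds share one core and differ only in the aromatic group attached through the oxygen. Compound 3 holds no separate rank among them. The measurements show a 1.3-fold higher number from compound 1 to compound 3 (0.11 log units; within the scatter) and a 1.5-fold lower number from compound 2 to compound 3 (0.16 log units; within the scatter), so its value cannot be told apart from either neighbour. The remaining pair gives the same picture, with a 1.9-fold higher number from compound 1 to compound 2 (0.27 log units; within the scatter).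

The next compound to be tested, compound 4 `CC(C)[C@H](NC(=O)COc1cccc2ccccc12)C(=O)N[C@@H](CC(=O)O)C(=O)COc1c(F)cccc1F`, turns the 2-fluorophenyl of compound 3 into 2,6-difluorophenyl: fluoro in place of hydrogen on an aromatic carbon. In words, this is fluoro in place of hydrogen on an aromatic carbon, ortho to a large group. For the measured compounds named here, no measured pair makes this exact change, so the evidence is indirect. Replacing the whole aromatic group, as in the steps above, never moved the number beyond the scatter, and adding one fluoro is a smaller edit. A step beyond the scatter is therefore not expected in this assay, although a single new fluoro could still surprise. The expected step is a 1.2-fold lower number from compound 3 to compound 4 (0.08 log units; within the scatter). For compound 4 the estimated value is 13000 nM, with an expected range from 6000 nM to 28000 nM.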

Compound 4, half-maximal inhibitory concentration: > 100000 nM
Compound 4 was reported as a limit (the forecaster's own chance of this, stated with the estimate: 3%); middle value at least 7.6-fold (0.88 log units) from the limit.
By their numbers in this assay, from the lowest: compounds 1, 3 and 2 (each within the scatter of the next). At a limit, above all of these: compound 4.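

In this assay, a single fluoro in place of hydrogen on an aromatic carbon, ortho to a large group, gives an at least 6.3-fold higher number from compound 3 to compound 4 (0.80 log units; beyond the scatter), whereas swapping the whole aromatic group among compound 1, compound 2 and compound 3 gave no step beyond the scatter. The 2,6-difluorophenyl group also stands apart from the other two aromatic groups, with an at least 4.3-fold higher number from compound 2 to compound 4 (0.64 log units; beyond the scatter) and an at least 8.1-fold higher number from compound 1 to compound 4 (0.91 log units; beyond the scatter), so the tolerance seen across the first three compounds does not extend to every group at this position, and even a change of one atom can matter here. Compound 4 is reported only as a limit, so each of these steps gives a minimum size and its full size remains unknown: the limit of > 100000 nM in this assay, at which 1 of the 4 values shown sits.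

The compounds shown give no reason for this step, so the fluoro's role remains unexplained. They also leave open whether a chloro or a methyl group in the same place, ortho to a large group, would give a step like that of the fluoro in compound 4 or stay within the scatter of compound 3.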